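Replacing the 4-carboxy-1-methylcyclohexyl group of compound 1

The compounds below may be only part of what the source reports. "The series", "measured", "known", "first", "only" and "open" are said of these compounds alone.

Measured compounds:
- compound 1 `C[C@]1(C(=O)N2CC[C@](c3ccc(C(F)(C(F)(F)F)C(F)(F)F)cc3)(S(=O)(=O)c3ccc(F)cc3)C2)CC[C@H](C(=O)O)CC1`: 80%
- compound 2 `CCC[C@]1(C(=O)N2CC[C@](c3ccc(C(F)(C(F)(F)F)C(F)(F)F)cc3)(S(=O)(=O)c3ccc(F)cc3)C2)CC[C@H](C(=O)O)CC1`: "not determined" (no result reported)
- compound 3 `O=C(O)C12CCC(C(=O)N3CC[C@](c4ccc(C(F)(C(F)(F)F)C(F)(F)F)cc4)(S(=O)(=O)c4ccc(F)cc4)C3)(CC1)CC2`: 100%

In an ADME assay on microsomes from liver (Homo sapiens) for metabolic stability, with a stated time of 10 min (a lower number here means that less of the compound is left, a higher number that more of the compound is left), compound 1 gives 80%, the lower of the two numbers available, as compound 2 has no number. The next compound to test is compound 4 `O=C(O)C12CCC(C(=O)N3CC[C@](c4ccc(C(F)(C(F)(F)F)C(F)(F)F)cc4)(S(=O)(=O)c4ccc(F)cc4)C3)(CC1)OC2`, and the change is a group of 11 heavy atoms (8 carbon, 3 oxygen; one six-membered non-aromatic ring of carbon only, one six-membered non-aromatic ring with 1 hetero atom) in place of a group of 10 heavy atoms (8 carbon, 2 oxygen; one six-membered non-aromatic ring of carbon only), on a carbonyl carbon. Within the data shown here, one measured step bears on it: a number 20 percentage points higher from compound 1 to compound 3 (beyond the scatter). That step also replaces the same group on the carbonyl carbon, but the group entering compound 4 has a six-membered non-aromatic ring with 1 hetero atom, so the transfer is uncertain. A step of similar size in the same direction is expected: a number 15 percentage points higher from compound 1 to compound 4 (beyond the scatter). For compound 4 the estimated value is 95%, with an expected range of 80% to 100%.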

Compound 4, percent of the compound remaining: 90%
Beside the measured number, compound 4's estimate is 5 percentage points above it; the range from low to high includes it.
By their numbers in this assay, from the lowest: compounds 1, 4 and 3 (each within the scatter of the next, the first and the last beyond it).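

In this assay, placing a six-membered non-aromatic ring with 1 hetero atom in the group on the carbonyl carbon gives a number 10 percentage points higher from compound 1 to compound 4 (within the scatter) and a number 10 percentage points lower from compound 3 to compound 4 (within the scatter). Compound 4 therefore separates from neither compound, although the two all-carbon groups differ by a number 20 percentage points higher from compound 1 to compound 3 (beyond the scatter), and the position accepts this ring oxygen without a step beyond the scatter. No available measurement accounts for these steps. Still open, as far as these compounds go, is how a ring nitrogen in place of that oxygen would read in this assay, and whether a primary amide in place of the carboxylic acid would hold the number.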